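Swapping Furan for Methylpyridine on the Core of Compound 1

This account rests on a few compounds, and the source may have more. Where it says the series, first, only, none or still open, it means among the compounds named here.

Among the compounds with values here, compound 1 `O=C(O)Cc1sc(C(c2ccc(F)cc2)c2ccc(F)cc2)nc1-c1ccco1` gives the lowest of the two numbers measured so far in an in vitro functional assay on HEK285-7 cells for antagonist activity at prostaglandin D2 receptor 2 (Homo sapiens), read by BRET and beta-arrestin recruitment; on this read-out lower numbers stand for stronger inhibition and higher numbers for weaker inhibition: compound 1 gives 140 nM, while compound 2 `O=C(O)Cc1sc(C2COc3ccccc3O2)nc1-c1ccc(Cl)cc1` gives 2000 nM, a gap beyond the usual scatter. Compound 3 `Cc1cc(-c2nc(C(c3ccc(F)cc3)c3ccc(F)cc3)sc2CC(=O)O)ccn1` differs from compound 1 in a single place: 2-methylpyridin-4-yl in place of furan-2-yl on an aromatic carbon. No comparable change has yet been measured, so the outlook rests on compound 1 alone. A modest step toward a weaker result is expected, namely a 1.8-fold higher number from compound 1 to compound 3 (0.25 log units; within the scatter). Compound 3 is therefore estimated at 250 nM, with a range from 70 nM to 900 nM.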

Compound 3, half-maximal inhibitory concentration: 53 nM
Compound 3: the middle estimate sits 4.7-fold (0.67 log units) above what was measured; measured number outside the range, below it.
By their numbers in this assay, from the lowest: compound 3; then compound 1; then compound 2.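

The position next to the ring nitrogen is not tied to a five-membered aromatic ring: in this assay, replacing furan-2-yl with 2-methylpyridin-4-yl gives a 2.6-fold lower number from compound 1 to compound 3 (0.42 log units; beyond the scatter). The larger six-membered aromatic ring, carrying a methyl group, therefore fits this position and gives stronger inhibition. Nothing measured here explains the gain. Going by these compounds, it remains open whether the gain follows the pyridine ring or its methyl group, which an unsubstituted pyridin-4-yl would help separate. On these data alone, how an amine or a longer chain in place of that methyl would read is also open.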